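The source may hold more compounds than are shown below. What is called first, only, known or untested is meant among the compounds shown, and "the series" means these compounds.

Compound 1 `Cc1ccccc1C(=O)N(C)c1ccc(C(O)(C(F)(F)F)C(F)(F)F)cc1` gives 38000 nM in an ADME assay on Li23 cells (Homo sapiens) for cytotoxicity, read by WST assay; a lower number here means that less compound is tolerated, a higher number that more compound is tolerated.
Compound 2 `CN(C(=O)c1cccnc1)c1ccc(C(O)(C(F)(F)F)C(F)(F)F)cc1` gives 63000 nM.
Compound 3 `CN(c1ccc(C(O)(C(F)(F)F)C(F)(F)F)cc1)S(=O)(=O)c1ccccc1` gives 16000 nM.

Compound 3 stands lowest of the three numbers in this assay. Its nearest neighbour is compound 1, with a 2.4-fold lower number from compound 1 to compound 3 (0.38 log units; beyond the scatter); the step of a 3.9-fold lower number from compound 2 to compound 3 (0.60 log units; beyond the scatter) is larger. Between the two amides the step is a 1.7-fold higher number from compound 1 to compound 2 (0.22 log units; within the scatter).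

Compound 4 `Cc1ccccc1S(=O)(=O)N(C)c1ccc(C(O)(C(F)(F)F)C(F)(F)F)cc1` is the next step from compound 3, with the change (methyl in place of hydrogen on an aromatic carbon). Going by the values given here, no measured step tests this change on its own. The nearest is the step from compound 1 to compound 3, where the departing (2-methylphenyl)carbonyl carried a methyl on its ring and the entering phenylsulfonyl did not; but the linking group changed at the same time, so the share of the methyl in that step cannot be separated. The step from compound 1 to compound 2, in which the 2-methylphenyl left and a pyridin-3-yl entered, stayed within the scatter. On this evidence no step beyond the scatter is expected from compound 3 to compound 4, and compound 4 is expected to show no change at the digits printed from compound 3 to compound 4 (within the scatter). The estimate for compound 4 in this assay is 16000 nM, with a range from 7000 nM to 36000 nM.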

Compound 4, half-maximal cytotoxic concentration: 12000 nM
Estimate against measurement, compound 4: 1.3-fold (0.12 log units) above; the measured number falls inside the stated range.
By their numbers in this assay, from the lowest: compounds 4 and 3 (each within the scatter of the next); then compounds 1 and 2 (each within the scatter of the next).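

In this assay, going by these compounds alone, methyl in place of hydrogen on an aromatic carbon, ortho to a large group, gives a 1.3-fold lower number from compound 3 to compound 4 (0.12 log units; within the scatter), and this pair isolates a change that the earlier compounds showed only together with a change of the linking group. In this sulfonyl pair, then, going from phenyl to 2-methylphenyl leaves the number within the scatter, a finding that applies to compound 3 and compound 4 alone and does not divide the step of a 2.4-fold lower number from compound 1 to compound 3 (0.38 log units; beyond the scatter) into shares for the methyl and the linking group. No measurement shown here offers an explanation for how the number responds to this methyl.

Whether the same methyl would also stay within the scatter with the carbonyl link of compound 1 remains open, as the shared core with an unsubstituted phenyl on that carbonyl is absent from the compounds shown. On these data alone, it is also open how this position would respond to a group other than methyl, such as a chlorine, a methoxy, an amine or a carboxylic acid, or to a longer chain such as an ethyl.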